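This account rests on a few compounds, and the source may have more. Where it says the series, first, only, none or still open, it means among the compounds named here.

Of the compounds shown here, two have so far been measured in a physicochemical assay for solubility, in phosphate buffer; on this read-out higher numbers stand for higher solubility and lower numbers for lower solubility. Compound 1 (`C[C@H](CO)N1C[C@H](C)[C@H](CN(C)Cc2ccc(Oc3ccccc3)cc2)Oc2c(NC(=O)c3ccncc3)cccc2C1=O`) gives 98000 nM, and compound 2 (`C[C@H]1CN([C@@H](C)CO)C(=O)c2cccc(NC(=O)c3ccncc3)c2O[C@@H]1CN(C)Cc1ccccc1`) gives 100000 nM. These two numbers lie within the usual scatter of each other, so compound 1 stands level with compound 2, and nothing separates them on this read-out. Still unmeasured is compound 3 (`C[C@@H]1CN([C@@H](C)CO)C(=O)c2cccc(NC(=O)c3ccncc3)c2O[C@@H]1CN(C)Cc1ccc(Oc2ccccc2)cc1`), which is related to compound 1 by a purely stereochemical change: the two compounds have the same atoms and bonds and differ only in configuration as drawn: 3 of 3 stereo elements differ (all stereocentres are inverted: mirror images); a stereocentre at a saturated ring carbon is drawn S in compound 1 and R in compound 3; a stereocentre at a saturated chain carbon is drawn R in compound 1 and S in compound 3; a stereocentre at a saturated ring carbon is drawn R in compound 1 and S in compound 3. The two compounds have the same atoms and bonds, and all stereocentres are inverted, which makes them mirror images. Within the data shown here, no step between measured compounds is available as a guide, so the data offer no direct precedent for such an inversion in this assay. The expectation therefore rests on the identical atoms and bonds and on the value of compound 1 at 98000 nM. No change beyond the scatter is expected in either direction, and the expected step of a 1.0-fold lower number from compound 1 to compound 3 (0.01 log units; within the scatter) is correspondingly small. For compound 3 the estimated value is 95000 nM, with an expected range from 60000 nM to 125000 nM.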

Compound 3, solubility: 87000 nM
The estimate for compound 3 lay 1.1-fold (0.04 log units) above the measured number, and the stated range covers the measured number.
By their numbers in this assay, from the lowest: compounds 3, 1 and 2 (each within the scatter of the next).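

In this assay, among these compounds, inverting all three stereocentres together comes with a 1.1-fold lower number from compound 1 to compound 3 (0.05 log units; within the scatter), and this is the first step in the set that can be read between two compounds with the same atoms and bonds. The earlier compounds shown here offered no such step, whereas this pair shows that, on this read-out, full inversion of the configuration as drawn leaves the mirror-image pair level, with nothing separating them beyond the scatter. The comparison isolates configuration alone, with no group leaving or entering, and the result rests on a single pair whose only difference is this one: the fact that compounds 1 and 3 differ only in the configuration as drawn.

The compounds shown leave open what happens when only one or two of the three stereocentres are inverted, which would give compounds that are no longer mirror images of compound 1, since here all three change at once. Among the compounds shown here, they also leave open whether a carboxylic acid or a longer chain on the shared core would move the number beyond the scatter, as the only step available stays within it.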